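The source may report more compounds than this note shows. Statements on the series, on what has been measured and on what is new or still open speak of the compounds shown alone.

Measured compounds:
Compound 1 `O=c1cc(CSc2nc3ccccc3c(=O)[nH]2)c2ccc(OS(=O)(=O)c3ccccc3[N+](=O)[O-])cc2o1` gives 144000 nM in an ADME assay on Vero cells (Chlorocebus sabaeus) for cytotoxicity, read by polymerase chain reaction, with a stated time of 18 h; on this read-out higher numbers stand for lower toxicity in this test and lower numbers for higher toxicity in this test.
Compound 2 `Cc1ccc2nc(SCc3cc(=O)oc4cc(OS(=O)(=O)c5ccccc5)ccc34)[nH]c(=O)c2c1` gives 126000 nM in this assay.
Compound 3 `Cc1ccc(S(=O)(=O)Oc2ccc3c(CSc4nc5ccc(C)cc5c(=O)[nH]4)cc(=O)oc3c2)cc1` gives 114000 nM in this assay.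

Compound 3 holds the smallest number of the three, yet its gaps to compound 2 and to compound 1 are both within the scatter. Among the measured compounds shown here, the only single-point step measured, a 1.1-fold lower number from compound 2 to compound 3 (0.04 log units; within the scatter), is also within the scatter. Compound 4 `Cc1ccc2nc(SCc3cc(=O)oc4cc(OS(=O)(=O)c5ccccc5[N+](=O)[O-])ccc34)[nH]c(=O)c2c1` differs from compound 3 by 2-nitrophenyl in place of 4-methylphenyl on a sulfonyl sulfur. For the measured compounds named here, no measured step covers this exchange; compound 1, which carries the same 2-nitrophenyl group on the sulfonyl sulfur, gives 144000 nM. Compound 4 is therefore expected to show no step beyond the scatter, a 1.2-fold higher number from compound 3 to compound 4 (0.07 log units; within the scatter), and is estimated at 135000 nM in this assay, within 80000 nM to 220000 nM.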

Compound 4, half-maximal cytotoxic concentration: 107000 nM
Beside the measured number, compound 4's estimate is 1.3-fold (0.10 log units) above it; the measured number falls inside the stated range.
By their numbers in this assay, from the lowest: compounds 4, 3, 2 and 1 (each within the scatter of the next).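

Direct exchange of 4-methylphenyl for 2-nitrophenyl on the sulfonyl sulfur gives a 1.1-fold lower number from compound 3 to compound 4 (0.03 log units; within the scatter) in this assay and so separates these two groups by no more than the scatter. A nitro group alone likewise gives a 1.2-fold lower number from compound 2 to compound 4 (0.07 log units; within the scatter) on the shared core. Methyl in place of hydrogen on an aromatic carbon, with a 1.3-fold lower number from compound 1 to compound 4 (0.13 log units; within the scatter) as its second reading, behaves alike on two cores: the same change on two cores in this assay, a 1.1-fold lower number (0.04 log units; within the scatter) from compound 2 to compound 3 and a 1.3-fold lower number (0.13 log units; within the scatter) from compound 1 to compound 4, 1.2-fold (0.09 log units) apart, within the scatter of two such steps.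

The groups shown on the sulfonyl sulfur are all six-membered aromatic rings of carbon only, so how an amine or a longer alkyl chain there would read in this assay stays open. Going by these compounds, whether any change at this position moves the number beyond the scatter also stays open.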